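Nitrone triazole series: fluoro to trifluoromethyl on the aryl

The source may hold more compounds than are shown below. What is called first, only, known or untested is meant among the compounds shown, and "the series" means these compounds.

Measured so far:
compound 1, `[O-]/[N+](=C\c1cn(-c2ccc(F)cc2)nn1)c1ccccc1`, 12500 nM
compound 2, `[O-]/[N+](=C\c1cn(-c2ccc(F)cc2)nn1)Cc1ccccc1`, > 100000 nM

In a functional assay on A549 cells (Homo sapiens) for inhibition, read by MTT assay, with a stated time of 24 h (a lower number here means a stronger inhibitor, a higher number a weaker inhibitor), compound 1 gives 12500 nM. Compound 2 gives no number, only a limit of this assay, > 100000 nM, as shown by the limit of > 100000 nM in this assay, at which 1 of the 2 values shown sits. Going by the values given here, the one measured step, an at least 8.0-fold higher number from compound 1 to compound 2 (0.90 log units; beyond the scatter), alters the group on the double-bonded nitrogen and so does not touch the aryl on the triazole. Compound 3, `[O-]/[N+](=C\c1cn(-c2ccc(C(F)(F)F)cc2)nn1)Cc1ccccc1`, differs from compound 2 by trifluoromethyl in place of fluoro on an aromatic carbon. Among the compounds with values here, no measured step concerns this change. Compound 3 is therefore expected to remain near the limit, with a number no higher from compound 2 to compound 3 (the limit leaves the size open) meaning no shift beyond the scatter. The estimate for compound 3 is 100000 nM, between 30000 nM and 300000 nM.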

Compound 3, half-maximal inhibitory concentration: > 100000 nM
Compound 3: only a limit was reported; the forecaster's own chance of this, stated with the estimate: 70%; the middle value sits exactly at the limit.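

Compound 2 and compound 3 are both reported only as limits, so no step can be read between them: the limit of > 100000 nM in this assay, at which 2 of the 3 values shown sit. On these data alone, whether trifluoromethyl in place of fluoro shifts the number at all in this assay stays open.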